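A few compounds are considered here, and "the series" means these few. Any claim that something is new, unique, unknown or untested is made for them only; others in the source may bear on it.

Compound 1 `CCCCc1cc(OC)c2ccccc2c1OC(C)=O` and compound 2 `CCCCc1cc(OC)c2ccccc2c1O` share one core, and compound 3 `CCCCc1cc(OC)c2sccc2c1OC(C)=O` and compound 4 `CCCCc1cc(OC)c2sccc2c1O` share another; the difference between the two cores is not broken down here. In a functional assay for inhibition, with Rattus norvegicus as the target (on this read-out higher numbers stand for weaker inhibition and lower numbers for stronger inhibition), compound 1 gives 440 nM, and in this assay compound 2 gives 1470 nM. Compound 2 differs from compound 1 in one place (hydrogen in place of acetyl on an oxygen on an aromatic ring). That single change produced a 3.3-fold higher number from compound 1 to compound 2 (0.52 log units; beyond the scatter).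

In this assay compound 3 gives 460 nM, a number that sits close to that of compound 1. Compound 4 differs from compound 3 in exactly the same way (hydrogen in place of acetyl on an oxygen on an aromatic ring), at a place whose surroundings read the same in both pairs. The change occurs twice among these four compounds, so the only guide to its effect on the second core is what it did on the first.

On that basis the step from compound 3 to compound 4 in this assay is expected to be about a 3.3-fold higher number from compound 3 to compound 4 (0.51 log units; beyond the scatter), resting on the step seen because a 3.3-fold higher number from compound 1 to compound 2 (0.52 log units; beyond the scatter) was recorded for the same change. For compound 4 the expected value in this assay is 1500 nM, most likely between 800 nM and 2900 nM.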

Compound 4, half-maximal inhibitory concentration: 1050 nM
Compound 4: middle estimate off by 1.4-fold (0.15 log units), on the high side; the measured number falls inside the stated range.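

Going from acetoxy to hydroxy on the second core gives a 2.3-fold higher number from compound 3 to compound 4 (0.36 log units; beyond the scatter) in this assay, so the number moves in the same direction as on the first core, towards weaker inhibition. The size of the step also carries over from one core to the other, as far as these data can tell: the same change on two cores in this assay, a 3.3-fold higher number (0.52 log units; beyond the scatter) from compound 1 to compound 2 and a 2.3-fold higher number (0.36 log units; beyond the scatter) from compound 3 to compound 4, 1.5-fold (0.17 log units) apart, within the scatter of two such steps. Going by these compounds alone, this rests on only two matched pairs, so it supports carrying the change between these two cores but does not show that it would hold on any other core, and it does not explain why removing the acetyl weakens inhibition.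

The compounds shown leave open whether a different group on that oxygen, such as a methyl or a longer acyl group like propionyl, would give numbers closer to the acetoxy or the hydroxy compounds. Within the data shown here, they also leave open whether an amine in place of that oxygen, or a longer chain than the one all four compounds share, would change the picture.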